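The compounds below may be only part of what the source reports. "The series", "measured", "known", "first", "only" and "open" are said of these compounds alone.

Working notes on the series. Two compounds carry numbers in a functional assay for agonist activity at 5-hydroxytryptamine receptor 4 (Homo sapiens), read by cAMP accumulation; on this read-out lower numbers stand for an effect already at smaller amounts and higher numbers for an effect only at larger amounts of compound. Compound 1, `CS(=O)(=O)N1CCN(CC(O)CN2CCC(CNC(=O)c3cccc4[nH]cnc34)CC2)CC1`, gives 10 nM. Compound 2, `CC(C)c1nc2c(C(=O)NCC3CCN(CCN4CCN(S(C)(=O)=O)CC4)CC3)cccc2[nH]1`, gives 0.794 nM, the lowest of the two values; compound 1 is the nearest neighbour and stands beyond the usual scatter above it. Going by the values given here, no single-point step between the two is drawn here, since compound 1 and compound 2 differ in more than one place, so only the two values themselves are of use.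

Compound 3, `COC(=O)N(C)CC(O)CN1CCC(CNC(=O)c2cccc3[nH]c(C(C)C)nc23)CC1`, awaits measurement in this assay. From compound 2 it differs by 1-hydroxy-2-((methoxycarbonyl)(methyl)amino)ethyl in place of (4-(methylsulfonyl)piperazin-1-yl)methyl on a saturated chain carbon bound to an amine nitrogen in a ring. The change removes the ring-bearing group that both measured compounds share and brings in a hydroxyl and a carbamate in its place; nothing measured in the series speaks directly to this exchange. Among the compounds with values here, compound 1, the only other compound with a hydroxyl on the chain, sits above compound 2 in this assay, but it also lacks the isopropyl on the core, so the two factors cannot be separated.

The expectation is a moderate loss, the step from compound 2 to compound 3 estimated at a 6.3-fold higher number from compound 2 to compound 3 (0.80 log units; beyond the scatter). Compound 3 is estimated at 5 nM, with a range from 1.5 nM to 20 nM.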

Compound 3, half-maximal effective concentration: 2 nM
The estimate for compound 3 lay 2.5-fold (0.40 log units) above the measured number; low and high end bracket the measured number.
By their numbers in this assay, from the lowest: compound 2; then compound 3; then compound 1.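

In this assay, going by these compounds alone, placing 1-hydroxy-2-((methoxycarbonyl)(methyl)amino)ethyl where (4-(methylsulfonyl)piperazin-1-yl)methyl stood, on a saturated chain carbon bound to an amine nitrogen in a ring, gives a 2.5-fold higher number from compound 2 to compound 3 (0.40 log units; beyond the scatter), the first step between compounds that differ in one place. The step is modest but beyond the scatter, and it shows that this position accepts an open group with no ring and 1 hydrogen-bond donor in place of a group with a six-membered non-aromatic ring and no hydrogen-bond donor, at the price of only a limited rise in the number, with compound 3 at 2 nM. No measurement at hand bears on why the step has this size.

The exchange alters the ring, the hydroxyl and the carbamate at once, so the share of each in the step stays unresolved. As far as these compounds go, it also remains open how the position would respond to a chain that keeps the hydroxyl but ends in a simple amide or a carboxylic acid in place of the carbamate.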